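Dithiocarbamate chromenone series: amine swap at the thiocarbonyl

The source may report more compounds than this note shows. Statements on the series, on what has been measured and on what is new or still open speak of the compounds shown alone.

In a functional assay on HEp-2 cells (Homo sapiens) for antiproliferative activity, read by MTT assay, with a stated time of 72 h (on this read-out lower numbers stand for stronger inhibition and higher numbers for weaker inhibition), compound 1 `CCN(CC)C(=S)SCc1cc(=O)c2ccc(Cl)cc2o1` gives 8800 nM, compound 3 `Cc1ccc2c(=O)c(CSC(=S)N3CCCC3)coc2c1` gives 3600 nM, and compound 2 `CCOC(=O)c1cc(=O)c2cc(CSC(=S)N(C(C)C)C(C)C)ccc2o1` gives 15900 nM. Compound 2 stands at the highest number of the three; its gap to compound 1 lies within the scatter, while its gap to compound 3 lies beyond it. Compound 4 `CCOC(=O)c1cc(=O)c2cc(CSC(=S)N3CCCC3)ccc2o1` keeps the core of compound 2 and carries pyrrolidin-1-yl in place of diisopropylamino on a thiocarbonyl carbon. Among the measured compounds shown here, no pair of measured compounds differs in one place only, so no single-change step is available. The step is expected to be small and toward a lower number, likely within the scatter, as a 1.8-fold lower number from compound 2 to compound 4 (0.25 log units; within the scatter). Compound 4 is estimated at 9000 nM, with a range from 3000 nM to 27000 nM.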

Compound 4, half-maximal inhibitory concentration: 8900 nM
For compound 4 the middle estimate is 1.0-fold (0.00 log units) above the measured one; the measured number falls inside the stated range.
By their numbers in this assay, from the lowest: compound 3; then compounds 1, 4 and 2 (each within the scatter of the next).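

In this assay, the series now has its first comparison that differs in one place: pyrrolidin-1-yl in place of diisopropylamino on a thiocarbonyl carbon gives a 1.8-fold lower number from compound 2 to compound 4 (0.25 log units; within the scatter). On the core of compound 2, this swap therefore does not separate the two amino groups beyond the scatter. No measured evidence bearing on this step is available.

Open, from the compounds shown here alone, is whether a piperidin-1-yl or morpholin-4-yl group at this position would give a step beyond the scatter. Also open, going by these compounds, is whether the same swap behaves alike on the core of compound 3.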